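This account rests on a few compounds, and the source may have more. Where it says the series, first, only, none or still open, it means among the compounds named here.

Among the compounds with values here, in an ADME assay on cells (Epithelial cell, Homo sapiens) for antiproliferative activity, read by MTT assay, with a stated time of 48 h (a higher number here means a weaker inhibitor, a lower number a stronger inhibitor), compound 1 (`COC(=O)/C(=C/c1ccccc1)CN1C(=O)[C@@H](OC)[C@H]1c1ccc(Cl)cc1Cl`) gives 70000 nM as the only number. Compound 2 (`COC(=O)/C(=C/c1ccccc1)CN1C(=O)[C@@H](OC)[C@H]1c1ccc(OC)cc1`) is reported as "not toxic" (no number reported) without a number, so it has no exact place on the scale and offers no numerical starting point. Compound 3 (`COC(=O)/C(=C/c1ccccc1)CN1C(=O)[C@@H](OC)[C@H]1c1cccc([N+](=O)[O-])c1`) keeps the shared core but carries 3-nitrophenyl in place of 4-methoxyphenyl on a saturated ring carbon. The size of this step in this assay cannot be fixed from compound 2. The expected direction is from a report of no toxicity towards a measurable but weak effect, not a large gain in potency. Within the data shown here, this expectation rests on compound 1 at 70000 nM as the sole numerical guide. The half-maximal inhibitory concentration of compound 3 is estimated at 60000 nM (expected range 20000 nM to 180000 nM).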

Compound 3, half-maximal inhibitory concentration: "not toxic" (no number reported)
No number was reported for compound 3; there is nothing to compare the estimate with.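

Compound 2 and compound 3 are both reported as "not toxic" in this assay without a number, so no step can be read between them. No supporting evidence bears on this result. The compounds shown leave open how compound 1 at 70000 nM compares with either on a numerical scale.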